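Dihydropyrimidine anilides: benzylsulfanyl chloro position, single oral dose

This account rests on a few compounds, and the source may have more. Where it says the series, first, only, none or still open, it means among the compounds named here.

Measured compounds:
compound 1, `CC1=C(C(=O)Nc2ccc(F)cc2)C(c2ccc([N+](=O)[O-])cc2)N=C(SCc2ccccc2Cl)N1`: 11.3%
compound 2, `CC1=C(C(=O)Nc2ccc(F)cc2)C(c2ccc([N+](=O)[O-])cc2)N=C(SCc2cccc(Cl)c2)N1`: 10.8%
compound 3, `CC1=C(C(=O)Nc2ccc(Br)cc2)C(c2ccc(Cl)cc2Cl)N=C(SCc2ccccc2Cl)N1`: 16.4%

All three compounds were run in a functional assay on the whole organism (artery, strain albino) with Rattus norvegicus as the target, with a stated time of 900 min, at a dose of 10 mg/kg by the oral route; on this read-out higher numbers stand for more inhibition at the one dose given (going by the name of the read-out) and lower numbers for less inhibition. Compound 1 gives 11.3% and compound 2 gives 10.8%; the two are within the scatter of each other, so no order between them is claimed. Compound 3 gives 16.4%. Its values against compound 1 and compound 2 also lie within the scatter, so compound 3 is not set apart from them here.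

Among the compounds with values here, the one change that is made twice in this set is 3-chlorophenyl in place of 2-chlorophenyl on a saturated chain carbon bound to a sulfur. Between compound 1 and compound 2 it produces a number 0.5 percentage points lower from compound 1 to compound 2 (within the scatter). The cores of compound 1 and compound 3 are different, but the difference between the two cores is not broken down here; the anilide and the aryl group carried on the core are not the same in the two.

Compound 4, `CC1=C(C(=O)Nc2ccc(Br)cc2)C(c2ccc(Cl)cc2Cl)N=C(SCc2cccc(Cl)c2)N1`, has not yet been measured in this assay. It stands to compound 3 as compound 2 stands to compound 1: 3-chlorophenyl in place of 2-chlorophenyl on a saturated chain carbon bound to a sulfur. The place of the change reads the same in both pairs, so this is the same kind of change on a different core.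

Within the data shown here, the expectation for compound 4 rests only on the one earlier instance. Because a number 0.5 percentage points lower from compound 1 to compound 2 (within the scatter) sat within the scatter, the step from compound 3 to compound 4 is expected to be small as well, about a number 0.4 percentage points lower from compound 3 to compound 4 (within the scatter). Compound 4 is therefore estimated at 16%, with a range from 7% to 25%. Among the measured compounds shown here, only one prior pair supports this, and compound 3 sits on a different core, so the range is kept wide.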

Compound 4, a percentage reported as inhibition, in the whole organism at one dose (the size of the read-out at that dose, not a potency): 7.2%
Compound 4: middle estimate off by 8.8 percentage points, on the high side, within the range that was stated.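

In this assay, 3-chlorophenyl in place of 2-chlorophenyl on the core of compound 3 gives a number 9.2 percentage points lower from compound 3 to compound 4 (within the scatter). Set beside the earlier instance of the same change, this step is not separated from it by more than repeated measurement allows: the same change on two cores in this assay, a number 0.5 percentage points lower (within the scatter) from compound 1 to compound 2 and a number 9.2 percentage points lower (within the scatter) from compound 3 to compound 4, 8.7 percentage points apart, within the scatter of two such steps The two pairs therefore give no sign that the change behaves differently on the two cores, but they do not establish that it carries over unaltered, and neither step sets one chlorobenzyl placement apart from the other on its core.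

The compounds shown leave open what a plain benzyl, a methoxybenzyl or a longer alkyl chain on the sulfur would give in this assay. As far as these compounds go, the anilide and the aryl group on the core also change together between compound 1 and compound 3, so their separate contributions remain open.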